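Aryl swap on the shared core: cytotoxicity notes

This account rests on a few compounds, and the source may have more. Where it says the series, first, only, none or still open, it means among the compounds named here.

Measured so far in an ADME assay on BJ cells (Homo sapiens), read by MTT assay, with a stated time of 72 h; a lower number here means a stronger inhibitor, a higher number a weaker inhibitor:
- compound 1 `COc1ncnc2c1c(-c1ccsc1)cn2[C@@H]1O[C@H](CO)[C@@H](O)[C@H]1O`: 64300 nM
- compound 2 `COc1nc(N)nc2c1c(-c1ccccc1)cn2[C@@H]1O[C@H](CO)[C@@H](O)[C@H]1O`: the result is a limit of the assay, > 100000 nM
- compound 3 `COc1ncnc2c1c(-c1cccs1)cn2[C@@H]1O[C@H](CO)[C@@H](O)[C@H]1O`: 62800 nM

Compound 3 carries the lowest number of the two that are numbers; compound 1 sits next to it, and the step of a 1.0-fold lower number from compound 1 to compound 3 (0.01 log units; within the scatter) is within the scatter. One of the three results is a limit (the limit of > 100000 nM in this assay, at which 1 of the 3 values shown sits), so the series is read on two numbers only.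

Compound 4 `COc1ncnc2c1c(-c1ccccc1)cn2[C@@H]1O[C@H](CO)[C@@H](O)[C@H]1O` differs from compound 3 in one place: phenyl in place of thiophen-2-yl on an aromatic carbon. Among the compounds with values here, no measured step bears directly on this change; the only step in hand, a 1.0-fold lower number from compound 1 to compound 3 (0.01 log units; within the scatter), moves the sulfur within the five-membered ring and does nothing beyond the scatter. Compound 2 also bears phenyl, but it differs from compound 4 in a second place as well, so its limit cannot be read as a step. Within the data shown here, with no step of size to lean on, the expectation for compound 4 is a number near compound 3, with the step of a 1.1-fold higher number from compound 3 to compound 4 (0.05 log units; within the scatter) expected to stay within the scatter. The estimated value for compound 4 in this assay is 70000 nM, expected to fall between 30000 nM and 160000 nM.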

Compound 4, half-maximal inhibitory concentration: > 100000 nM
Compound 4: no number, only a limit; the forecaster's own chance of this, stated with the estimate: 30%; middle value at least 1.4-fold (0.15 log units) away from the limit.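

Phenyl in place of either thiophene ring moves this position out of the numeric range: compound 4 gives only a limit of the assay in this assay. The readable floors are an at least 1.5-fold higher number from compound 3 to compound 4 (0.20 log units; that floor lies within the scatter) and an at least 1.5-fold higher number from compound 1 to compound 4 (0.19 log units; that floor lies within the scatter), so the direction is upward from both thiophene compounds, yet neither floor alone shows a change beyond the scatter, and the thiophen-2-yl and thiophen-3-yl results gave no sign of this. The step that removes the amino group from compound 2 cannot be read, and the effect of amino on the phenyl compounds remains unknown, as both ends of that step are limits: the limit of > 100000 nM in this assay, at which 2 of the 4 values shown sit.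

On these data alone, the true size of the phenyl change remains open, as compound 4 has no number. Also open, as far as these compounds go, is whether a pyridyl ring or a furan-2-yl group on this aromatic carbon would give a number or a limit.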